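Replacing the Chain Amine: From Compound 1 to Compound 3

The compounds below may be only part of what the source reports. "The series", "measured", "known", "first", "only" and "open" are said of these compounds alone.

Measured so far:
Compound 1 `CN(C)CCCCCn1c2c(c3ccccc31)C(=O)c1c[n+]([O-])c3ccccc3c1C2=O` gives 370 nM in a functional assay on SH-SY5Y cells (Homo sapiens) for cytotoxicity, read by MTT assay, with a stated time of 72 h; on this read-out higher numbers stand for weaker inhibition and lower numbers for stronger inhibition.
Compound 2 `CC1(C)OCC(Cn2cc(Cn3c4c(c5ccccc53)C(=O)c3c[n+]([O-])c5ccccc5c3C4=O)nn2)O1` gives 230 nM in this assay.

Compound 1 holds the higher of the two numbers, but compound 2 lies within the usual scatter of it, so the two cannot be told apart on this read-out. Compound 3 `CCCCN1CCN(CCCCn2c3c(c4ccccc42)C(=O)c2c[n+]([O-])c4ccccc4c2C3=O)CC1` has not yet been measured. It differs from compound 1 in one place: 4-butylpiperazin-1-yl in place of (dimethylamino)methyl on a saturated chain carbon, four bonds along the chain from an aromatic nitrogen. Among the compounds with values here, no step between measured compounds touches this part of the chain, so nothing among the measured compounds speaks directly to the change. The account therefore expects only a small step, within the scatter and, if anything, toward a lower number, estimated as a 1.2-fold lower number from compound 1 to compound 3 (0.09 log units; within the scatter). Compound 3 is then expected to give about 300 nM in this assay, with a range from 120 nM to 750 nM.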

Compound 3, half-maximal inhibitory concentration: 6100 nM
Estimate against measurement, compound 3: 20-fold (1.31 log units) below, and the stated range ends below it.
By their numbers in this assay, from the lowest: compounds 2 and 1 (each within the scatter of the next); then compound 3.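

In this assay this part of the chain proves not to be indifferent: 4-butylpiperazin-1-yl in place of (dimethylamino)methyl gives a 16-fold higher number from compound 1 to compound 3 (1.22 log units; beyond the scatter) with the core of compound 1 unchanged. Within the data shown here, the readily exchanged end of the chain can therefore move this read-out strongly, which the earlier compounds could not show, since no step among them touched it. The change brings in a ring, a second nitrogen and a butyl group at once, and the compounds shown do not separate these parts, while nothing on hand gives a reason for the step.

Open, on these data alone, is whether a 4-methylpiperazin-1-yl or a piperidin-1-yl group in the same place would stay close to compound 1 or go the way of compound 3. Also open, as far as these compounds go, is how a morpholine ring or a simple diethylamino group would behave there.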